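The source may report more compounds than this note shows. Statements on the series, on what has been measured and on what is new or still open speak of the compounds shown alone.

In a physicochemical assay for solubility, read by HPLC (a higher number here means a more soluble compound, a lower number a less soluble compound), compound 3 `CC(=O)NC[C@H]1CN(c2ccc(OC[C@@H](O)CNC3CC3)c(F)c2)C(=O)O1` gives 96000000 nM, the highest number of the three, against compound 1 `CC(=O)NC[C@H]1CN(c2ccc(OC[C@H](O)CNc3ccccc3)c(F)c2)C(=O)O1` at 296000 nM and compound 2 `CC(=O)NC[C@H]1CN(c2ccc(OC[C@H](O)CNc3ccc(C#N)cc3)c(F)c2)C(=O)O1` at 69000 nM. Compound 4 `CC(=O)NC[C@H]1CN(c2ccc(OC[C@H](O)CNCCC(C)C)c(F)c2)C(=O)O1` brings one change: 1-hydroxy-2-(isopentylamino)ethyl in place of 2-(cyclopropylamino)-1-hydroxyethyl on a saturated chain carbon bound to an oxygen on an aromatic ring. Among the measured compounds shown here, no measured step covers this exchange directly. The closest guide is the large 320-fold higher number from compound 1 to compound 3 (2.51 log units; beyond the scatter), where 2-anilino-1-hydroxyethyl leaves. Compound 4 also lacks that group, so most of that rise is expected to hold. The modest 4.3-fold lower number from compound 1 to compound 2 (0.63 log units; beyond the scatter) concerns an aromatic carbon and bears only weakly. For the measured compounds named here, a modest fall in this assay is expected, with no measured step to fix its size. The estimated change is a 6.4-fold lower number from compound 3 to compound 4 (0.81 log units; beyond the scatter). The expected value for compound 4 is 15000000 nM, with an estimated range of 2000000 nM to 80000000 nM.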

Compound 4, solubility: 7280000 nM
Compound 4: middle estimate off by 2.1-fold (0.31 log units), on the high side, within the range that was stated.
By their numbers in this assay, from the lowest: compound 2; then compound 1; then compound 4; then compound 3.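

In this assay the non-aromatic amine substituents are not interchangeable: 1-hydroxy-2-(isopentylamino)ethyl in place of 2-(cyclopropylamino)-1-hydroxyethyl brings a 13-fold lower number from compound 3 to compound 4 (1.12 log units; beyond the scatter) at this position. Isopentyl on the amine nitrogen still stands clear of both aromatic substituents, with a 25-fold higher number from compound 1 to compound 4 (1.39 log units; beyond the scatter) and a 110-fold higher number from compound 2 to compound 4 (2.02 log units; beyond the scatter) in the same direction. No measured evidence accounts for these differences.

The compounds shown leave open how a morpholine or a carboxylic acid on the amine nitrogen would read here. They also leave open whether the fall with isopentyl follows chain length or the loss of the three-membered ring.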